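From compound 3 to compound 4: one group exchanged

A few compounds are considered here, and "the series" means these few. Any claim that something is new, unique, unknown or untested is made for them only; others in the source may bear on it.

compound 1 `O=C(CN1CCN(C(=O)c2cccc(Cl)c2)CC1)N1CCN(CCCc2c[nH]c3ccccc23)CC1`: 120000 nM
compound 2 `O=C(CN1CCN(C(=O)c2ccccc2)CC1)N1CCN(CCCc2c[nH]c3ccc(F)cc23)CC1`: 146000 nM
compound 3 `Cc1ccc(C(=O)N2CCN(CC(=O)N3CCN(CCCc4c[nH]c5ccc(F)cc45)CC3)CC2)cc1`: 119000 nM

All three compounds were measured in an ADME assay on SH-SY5Y cells (Homo sapiens) for cytotoxicity, read by MTT assay, with a stated time of 72 h (a higher number here means a weaker inhibitor, a lower number a stronger inhibitor), and their numbers lie within the usual scatter of one another, so compound 3 at 119000 nM stands level with the other two. Compound 4 `O=C(CN1CCN(C(=O)c2cccc(Cl)c2)CC1)N1CCN(CCCc2c[nH]c3ccc(F)cc23)CC1` has not been measured yet. It differs from compound 3 in one place, on a carbonyl carbon (3-chlorophenyl in place of 4-methylphenyl on a carbonyl carbon). Within the data shown here, one measured step touches the same group: methyl in place of hydrogen on an aromatic carbon gave a 1.2-fold lower number from compound 2 to compound 3 (0.09 log units; within the scatter) and so stayed within the scatter. The 3-chlorophenyl group also appears on a different core in compound 1, whose 120000 nM is within the scatter of compound 3. On this evidence, no step beyond the scatter is expected in this assay here. The expected step is a 1.1-fold higher number from compound 3 to compound 4 (0.02 log units; within the scatter) and should not be read as a real change. For compound 4 the estimated value is 125000 nM with an expected range from 70000 nM to 210000 nM in repeat measurements.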

Compound 4, half-maximal inhibitory concentration: 59800 nM
Estimate against measurement, compound 4: 2.1-fold (0.32 log units) above, outside the stated range (below it).
By their numbers in this assay, from the lowest: compounds 4, 3, 1 and 2 (each within the scatter of the next, the first and the last beyond it).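

Exchanging 4-methylphenyl for 3-chlorophenyl on a carbonyl carbon gives a 2.0-fold lower number from compound 3 to compound 4 (0.30 log units; within the scatter) in this assay, so this change stays within the scatter, and adding a fluoro group likewise gives a 2.0-fold lower number from compound 1 to compound 4 (0.30 log units; within the scatter). Among these compounds, the first step at this position to pass beyond the scatter comes with adding a chloro group, a modest 2.4-fold lower number from compound 2 to compound 4 (0.39 log units; beyond the scatter), whereas methyl in place of hydrogen gave only a 1.2-fold lower number from compound 2 to compound 3 (0.09 log units; within the scatter) and stayed within it. No measurement here accounts for this difference between chloro and methyl.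

The compounds shown leave open how an amine or a carboxylic acid on this phenyl ring would read in this assay. They also leave open whether a longer chain in place of the phenyl ring would keep the modest step seen with chloro.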